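Exchanging the amine-nitrogen group of compound 2

A few compounds are considered here, and "the series" means these few. Any claim that something is new, unique, unknown or untested is made for them only; others in the source may bear on it.

In a functional assay on MCF7 cells (Homo sapiens) for inhibition, read by MTT assay, with a stated time of 48 h (on this read-out higher numbers stand for weaker inhibition and lower numbers for stronger inhibition), compound 1 (`CCOC(=O)C(=NNC1=C(C(=O)OCC)C(c2ccc(N(C)C)cc2)c2c(C)n[nH]c2N1)C(=O)OCC`) gives 89800 nM and compound 2 (`CCOC(=O)C1=C(N/C=N/c2ccc(C)cc2)Nc2[nH]nc(C)c2C1c1ccc(N(C)C)cc1`) gives 50500 nM, so these two stand within the scatter of each other and neither can be ranked ahead. Compound 3 (`CCOC(=O)C1=C(N/N=C(/C(C)=O)C(=O)OCC)Nc2[nH]nc(C)c2C1c1ccc(N(C)C)cc1`) has not been measured. It differs from compound 2 on an amine nitrogen: a group of 10 heavy atoms (6 carbon, 1 nitrogen, 3 oxygen; no ring) in place of a group of 9 heavy atoms (8 carbon, 1 nitrogen; one six-membered aromatic ring of carbon only), on an amine nitrogen. Within the data shown here, the one measured step bearing on this is a 1.8-fold lower number from compound 1 to compound 2 (0.25 log units; within the scatter). That step put the group with the six-membered aromatic ring in place of a chain with no ring on the same nitrogen, and compound 3 returns to a chain with no ring. No shift beyond the scatter is therefore expected in this assay. The expected change is a 1.4-fold higher number from compound 2 to compound 3 (0.14 log units; within the scatter). Compound 3 is estimated at 70000 nM, with an expected range of 28000 nM to 170000 nM.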

Compound 3, half-maximal inhibitory concentration: > 100000 nM
Compound 3: no number, only a limit; the forecaster's own chance of this, stated with the estimate: 12%; at least 1.4-fold (0.15 log units) between middle value and limit.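

In this assay compound 3 reaches a limit of the assay and not a number (> 100000 nM). Exchanging the group on an amine nitrogen whose other neighbours are a double-bonded ring carbon gives an at least 1.9-fold higher number from compound 2 to compound 3 (0.29 log units; that floor lies within the scatter) and, against the other group with no ring, an at least 1.1-fold higher number from compound 1 to compound 3 (0.04 log units; that floor lies within the scatter) as well. Each of these is only a floor, so this position now holds a group whose true size of change is unknown and which cannot yet be ranked against compound 1 or compound 2: the limit of > 100000 nM in this assay, at which 1 of the 3 values shown sits.

On these data alone, it remains open whether the group of 10 heavy atoms reads beyond the scatter from compound 2 once a number replaces the limit. Also open, as far as these compounds go, is whether a carboxylic acid on the chain, or a pyridine ring on this nitrogen, would read apart from compound 2.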